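Nitro to aminomethyl on the coumarin-ester series, migration read-out

A few compounds are considered here, and "the series" means these few. Any claim that something is new, unique, unknown or untested is made for them only; others in the source may bear on it.

Measured so far:
compound 1 `O=C(Oc1cccc(F)c1)c1cc2cc([N+](=O)[O-])ccc2oc1=O` — 53.6%
compound 2 `O=C(Oc1cccc(Br)c1)c1cc2cc([N+](=O)[O-])ccc2oc1=O` — 35.2%
compound 3 `O=C(Oc1cccc(I)c1)c1cc2cc([N+](=O)[O-])ccc2oc1=O` — 63.6%

In a functional assay on HT-1080 cells (Homo sapiens), read by transwell migration, with a stated time of 24 h, tested at 1 uM (a higher number here means a weaker effect of the compound at the concentration tested, a lower number a stronger effect), compound 1 stands second highest of the three; compound 3 lies closest, by a number 10 percentage points higher from compound 1 to compound 3 (within the scatter), and compound 2 furthest, by a number 18.4 percentage points lower from compound 1 to compound 2 (beyond the scatter). The step to compound 4 `NCc1ccc2oc(=O)c(C(=O)Oc3cccc(F)c3)cc2c1` is aminomethyl in place of nitro on an aromatic carbon. Among the compounds with values here, none of the measured steps touches this position: all three exchange one halogen for another on the ester ring, with a number 28.4 percentage points higher from compound 2 to compound 3 (beyond the scatter) the largest of them. Within the data shown here, no measured step therefore bears on the change, and no direction is supported. The expected step is a number 1.4 percentage points higher from compound 1 to compound 4 (within the scatter), i.e. none beyond the scatter, with wide uncertainty. Compound 4 is estimated at 55%, range 30% to 80%.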

Compound 4, a percentage reported as activity, at one concentration (the size of the read-out at that concentration, not a potency): 45.3%
Beside the measured number, compound 4's estimate is 9.7 percentage points above it; the measured number falls inside the stated range.
By their numbers in this assay, from the lowest: compound 2; then compounds 4, 1 and 3 (each within the scatter of the next, the first and the last beyond it).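

At this position on the shared core, the first step available in this assay is a number 8.3 percentage points lower from compound 1 to compound 4 (within the scatter). With the fluoro ester ring held constant, replacing nitro with aminomethyl therefore gives no separation beyond the scatter, so nitro is not needed to keep the read-out in this range. No measured property is available to explain this result.

Still open, on these data alone, is whether aminomethyl gives the same outcome alongside the bromo ester of compound 2, at 35.2%. Also open, as far as these compounds go, is how a carboxylic acid or a longer aminoethyl chain would read at this position.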